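Removing a Trifluoromethyl Group on a Caspase-8 Inhibitor Scaffold

This account rests on a few compounds, and the source may have more. Where it says the series, first, only, none or still open, it means among the compounds named here.

Measured compounds:
compound 1, `O=C1C[C@H](NC(=O)[C@@H]2CNC[C@@H]3CCCC[C@H](NC(=O)c4nccc5ccccc45)C(=O)N32)C(O)O1`, 595 nM;
compound 2, `O=C1C[C@H](NC(=O)[C@@H]2COC[C@@H]3C/C=C\C[C@H](NC(=O)c4ccc(C(F)(F)F)cc4)C(=O)N32)C(O)O1`, 6450 nM;
compound 3, `O=C1C[C@H](NC(=O)[C@@H]2CN(C(=O)OCc3ccccc3)C[C@@H]3C/C=C\C[C@H](NC(=O)c4ccccc4)C(=O)N32)C(O)O1`, 13 nM.

These three compounds share a bicyclic core carrying an aromatic amide, and were tested in an assay on isolated protein for inhibition of Caspase-8 (Homo sapiens); on this read-out higher numbers stand for weaker inhibition and lower numbers for stronger inhibition. Compound 2 stands highest of the three numbers: compound 1 sits at a lower value, a gap beyond the usual scatter, and compound 3 sits lower still, also well beyond the scatter.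

Compound 4, `O=C1C[C@H](NC(=O)[C@@H]2COC[C@@H]3C/C=C\C[C@H](NC(=O)c4ccccc4)C(=O)N32)C(O)O1`, has not yet been measured. It differs from compound 2 in one place: hydrogen in place of trifluoromethyl on an aromatic carbon. In words, a hydrogen takes the place of a trifluoromethyl on an aromatic carbon, turning the (4-(trifluoromethyl)phenyl)carbonyl into a plain benzoyl.

Among the compounds with values here, no pair of measured compounds differs in exactly this way, so the size of the step is not directly anchored. Compound 3 also carries a benzoyl and gives 13 nM, but it differs from compound 2 in more than one place, so its value cannot be laid on this change alone. A moderate step toward stronger inhibition is expected in this assay, meaning from compound 2 to compound 4 a step of a 2.2-fold lower number from compound 2 to compound 4 (0.33 log units; beyond the scatter). Compound 4 is therefore estimated at 3000 nM, with a range from 800 nM to 12000 nM.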

Compound 4, half-maximal inhibitory concentration: 7900 nM
For compound 4 the middle estimate is 2.6-fold (0.42 log units) below the measured one; the measured number falls inside the stated range.
By their numbers in this assay, from the lowest: compound 3; then compound 1; then compounds 2 and 4 (each within the scatter of the next).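

In this assay, putting hydrogen where the trifluoromethyl stood gives a 1.2-fold higher number from compound 2 to compound 4 (0.09 log units; within the scatter), so the two compounds cannot be told apart on this read-out. Within the data shown here, this is the first direct look at this position, on an aromatic carbon of the six-membered aromatic ring and para to a large group, and on this core the four heavy atoms of the trifluoromethyl can go without any change that rises above the scatter. A plain benzoyl is also not enough on its own to give a low number, as compound 4 shows with 7900 nM in the same assay.

The compounds shown carry only hydrogen or trifluoromethyl at this position, so it remains open whether an amine, a carboxylic acid or a longer chain there would also leave the number in place. From the compounds shown here alone, it also remains open whether the same exchange would read the same way on the core of compound 3, whose number lies far lower. Nothing available here offers any explanation for why compound 2 and compound 4 read alike.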